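Cyclohexyl in place of phenyl on a shared core

The source may hold more compounds than are shown below. What is called first, only, known or untested is meant among the compounds shown, and "the series" means these compounds.

Measured so far in a functional assay on U-251 cells (Homo sapiens) for inhibition, read by sulforhodamine B assay, with a stated time of 72 h; on this read-out higher numbers stand for an effect only at larger amounts of compound and lower numbers for an effect already at smaller amounts
Compound 1 `CSc1ccc(C(=O)/C=C/c2ccc([N+](=O)[O-])o2)cc1` gives 14200 nM
Compound 2 `CC(C)(C)c1ccc(C(=O)/C=C/c2ccc([N+](=O)[O-])o2)cc1` gives 44500 nM
Compound 3 `O=C(/C=C/c1ccc([N+](=O)[O-])o1)c1ccc(-c2ccccc2)cc1` gives 24600 nM

With a 1.7-fold higher number from compound 1 to compound 3 (0.24 log units; within the scatter) and a 1.8-fold lower number from compound 2 to compound 3 (0.26 log units; within the scatter) on record, compound 3 stands within the scatter of both other compounds. Those two are themselves separated by more, as a 3.1-fold higher number from compound 1 to compound 2 (0.50 log units; beyond the scatter) shows.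

The next compound, compound 4 `O=C(/C=C/c1ccc([N+](=O)[O-])o1)c1ccc(C2CCCCC2)cc1`, carries cyclohexyl in place of phenyl on an aromatic carbon, with cyclohexyl in place of phenyl on an aromatic carbon as the counted difference. Among the compounds with values here, no measured compound carries cyclohexyl, so the evidence is indirect. The nearest guide is the exchange at this same place seen in a 1.8-fold lower number from compound 2 to compound 3 (0.26 log units; within the scatter) as it stayed within the scatter. The exchange in a 3.1-fold higher number from compound 1 to compound 2 (0.50 log units; beyond the scatter) is the largest seen here and is still modest. No step beyond the scatter is therefore expected. The expected step is a 1.2-fold higher number from compound 3 to compound 4 (0.09 log units; within the scatter) and it carries no firm direction. In this assay compound 4 is estimated at 30000 nM with 14000 nM to 62000 nM as the expected range.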

Compound 4, half-maximal effective concentration: 4400 nM
Compound 4: the middle estimate sits 6.8-fold (0.83 log units) above what was measured, outside the stated range (below it).
By their numbers in this assay, from the lowest: compound 4; then compounds 1, 3 and 2 (each within the scatter of the next, the first and the last beyond it).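

In this assay, within the data shown here, this position proves more sensitive than the earlier compounds suggested: phenyl and cyclohexyl have the same heavy-atom count and differ as an aromatic and a non-aromatic ring, yet the exchange gives a 5.6-fold lower number from compound 3 to compound 4 (0.75 log units; beyond the scatter). Cyclohexyl also separates clearly from the other two groups, with a 10-fold lower number from compound 2 to compound 4 (1.00 log units; beyond the scatter) against tert-butyl and a 3.2-fold lower number from compound 1 to compound 4 (0.51 log units; beyond the scatter) against methylsulfanyl, so compound 4 has the lowest number of the four, beyond the scatter of each. Nothing available here explains this result.

The compounds shown leave open whether this lower number is particular to cyclohexyl or would also appear with cyclopentyl, a longer chain such as hexyl, or an amine such as piperidine at this place. They also leave open whether the same exchange would have a similar effect on a different core.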